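The source may hold more compounds than are shown below. What is called first, only, known or untested is meant among the compounds shown, and "the series" means these compounds.

Compound 2, whose structure is `CC(C)CC(=O)NC1CCCN1C(=O)/C=C/c1ccccc1`, has been examined in a functional assay on LNCaP cells (Homo sapiens) for cytotoxicity; on this read-out lower numbers stand for an effect already at smaller amounts and higher numbers for an effect only at larger amounts of compound. In this assay compound 2 gives > 5 ug/mL, which is a limit of the assay rather than a number. Its neighbour compound 1, with the structure `C[S+]([O-])/C=C/C(=O)NC1CCCN1C(=O)/C=C/c1ccccc1`, is also known; in this assay compound 1 gives > 5 ug/mL, again only a limit. For the measured compounds named here, the step that the two limits leave unreadable from compound 1 to compound 2 therefore cannot be read, and the only evidence on the measured pair is the limit of > 5 ug/mL in this assay, at which 2 of the 2 values shown sit.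

The next compound, compound 3, has the structure `COC1CCCN1C(=O)/C=C/c1ccccc1`. It differs from compound 2 by methoxy in place of (isobutylcarbonyl)amino on a saturated ring carbon.

Going by the values given here, no measured step touches a change of this kind, and the single step that exists carries no readable size. With both known values sitting at the limit, there is no ground to expect compound 3 to move off it in either direction. Compound 3 is therefore expected to show 8 ug/mL, within a range of 3 ug/mL to 25 ug/mL. The expected step that the limit leaves unreadable from compound 2 to compound 3 means no change beyond the scatter, and most likely another limit.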

Compound 3, concentration for half-maximal effect: > 5 ug/mL
Compound 3: only a limit was reported; the forecaster's own chance of this, stated with the estimate: 70%; the middle value does not contradict the limit.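

In this assay compound 3 gives > 5 ug/mL and this is again only a limit. The step from compound 2 to compound 3 therefore cannot be read, and the evidence remains a single one: the limit of > 5 ug/mL in this assay, at which 3 of the 3 values shown sit. The compounds shown leave open at what concentration any of them acts, and whether methoxy in place of (isobutylcarbonyl)amino changes the read-out at all.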